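The source may report more compounds than this note shows. Statements on the series, on what has been measured and on what is new or still open speak of the compounds shown alone.

Working notes on the series in a functional assay on HCT-116 cells (Homo sapiens), read by MTT assay, with a stated time of 72 h; on this read-out higher numbers stand for weaker inhibition and lower numbers for stronger inhibition. Compound 1 `Nc1nc(N)c2c(-c3cc4ccccc4o3)cn([C@@H]3O[C@H](CO)[C@@H](O)[C@H]3O)c2n1` sits at the assay limit of > 20000 nM, a limit rather than a number. Compound 2 `Cc1nc(N)c2c(-c3cc4ccccc4o3)cn([C@@H]3O[C@H](CO)[C@@H](O)[C@H]3O)c2n1` likewise rests at the limit of > 20000 nM. Compound 3 `Cc1ncnc2c1c(-c1ccoc1)cn2[C@@H]1O[C@H](CO)[C@@H](O)[C@H]1O` also returns only the limit, > 20000 nM. The step that the two limits leave unreadable from compound 1 to compound 2, methyl in place of amino on an aromatic carbon, cannot be sized because every value stands at the limit of > 20000 nM in this assay, at which 3 of the 3 values shown sit. Compound 4 `Cc1nc(N)c2c(-c3ccccc3)cn([C@@H]3O[C@H](CO)[C@@H](O)[C@H]3O)c2n1` differs from compound 2 by phenyl in place of 1-benzofuran-2-yl on an aromatic carbon. Among the compounds with values here, no measured step bears on this change, and the three limits give neither size nor direction for it. In this assay compound 4 is expected to remain near the limit, estimated at 30000 nM within 8000 nM to 100000 nM. The expected step that the limit leaves unreadable from compound 2 to compound 4 is therefore none beyond the scatter.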

Compound 4, half-maximal inhibitory concentration: > 100000 nM
Compound 4 gave a limit, no number; the forecaster's own chance of this, stated with the estimate: 75%; middle value at least 3.3-fold (0.52 log units) from the limit.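

Compound 2 and compound 4 both give limits rather than numbers, and no step can be read between them. The compounds shown leave open whether any change on the shared core gives a measurable value in this assay.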